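Diterpenoid acid side-chain variants on SMMC-7721 cells

The source may hold more compounds than are shown below. What is called first, only, known or untested is meant among the compounds shown, and "the series" means these compounds.

Compound 1 `C=C1CC[C@@H]2[C@](C)(CCC[C@]2(C)C(=O)O)[C@H]1CC/C(C)=C/CO`: > 40000 nM
Compound 2 `C=CC(=C)[C@@H](O)C[C@H]1C(=C)CC[C@@H]2[C@]1(C)CCC[C@]2(C)C(=O)O`: > 40000 nM
Compound 3 `C=C1CC[C@@H]2[C@](C)(CCC[C@]2(C)C(=O)O)[C@H]1C/C=C(\C)C=O`: > 40000 nM

Series notes. In a functional assay on SMMC-7721 cells (Homo sapiens) for cytotoxicity, read by MTT assay, with a stated time of 48 h (a lower number here means a stronger inhibitor, a higher number a weaker inhibitor), compound 3 sits only at a limit, > 40000 nM, not at a number. Compound 1 likewise reports only a limit. Compound 2 reports only a limit. Going by the values given here, all three therefore share (the limit of > 40000 nM in this assay, at which 3 of the 3 values shown sit), and the steps a step that the two limits leave unreadable from compound 1 to compound 2, a step that the two limits leave unreadable from compound 1 to compound 3 and a step that the two limits leave unreadable from compound 2 to compound 3 cannot be read in size; they show only that three different side-chain groups on a saturated chain carbon bound to a saturated ring carbon leave the core inactive within this assay's window.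

Compound 4 `C=C[C@@](C)(O)CC[C@H]1C(=C)CC[C@@H]2[C@]1(C)CCC[C@]2(C)C(=O)O` carries a further side-chain change, (2-hydroxy-2-methylbut-3-en-1-yl in place of 2-formylprop-1-en-1-yl on a saturated chain carbon bound to a saturated ring carbon). The three unreadable steps bear on it only in that no side-chain exchange so far has brought a value inside the window. For compound 4 in this assay the expected step is therefore a step that the limit leaves unreadable from compound 3 to compound 4, most likely no change beyond the scatter. Compound 4 is estimated at 60000 nM, with a range from 20000 nM to 200000 nM, and another limit is the likely report.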

Compound 4, half-maximal inhibitory concentration: > 40000 nM
Compound 4: a limit, no number; the forecaster's own chance of this, stated with the estimate: 80%; the middle value is on the limit's open side.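

Compound 4, like compounds 1, 2 and 3, reports only a limit in this assay, so none of its steps to them can be read in size: the limit of > 40000 nM in this assay, at which 4 of the 4 values shown sit.

The compounds shown leave open whether any side-chain group on the shared core gives a value inside this window.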